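This account rests on a few compounds, and the source may have more. Where it says the series, first, only, none or still open, it means among the compounds named here.

Measured compounds:

Compound 1, `CC(=O)c1ccc2c(n1)c(S(=O)(=O)c1cccc(F)c1)cn2CCN(C)C` — in a functional assay on HeLa cells for antagonist activity at 5-hydroxytryptamine receptor 6 (Homo sapiens), read by cAMP accumulation and immunoassay (on this read-out higher numbers stand for weaker inhibition and lower numbers for stronger inhibition), compound 1 gives 41 nM.
Compound 2, `CC(=O)c1ccc2c(n1)c(S(=O)(=O)c1cccc3ccccc13)cn2CCN(C)C` — in this assay compound 2 gives 295 nM.
Compound 3, `NCCn1cc(S(=O)(=O)c2cccc(F)c2)c2ncccc21` — in this assay compound 3 gives 823 nM.

Compound 3 stands highest of the three numbers in this assay, so it is the weakest inhibitor among them; its nearest neighbour is compound 2 and the furthest is compound 1, both beyond the scatter.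

Compound 4, `NCCn1cc(S(=O)(=O)c2cccc(Cl)c2)c2ncccc21`, differs from compound 3 in one place: chloro in place of fluoro on an aromatic carbon. Going by the values given here, the only measured step that touches the group on the sulfonyl sulfur is a 7.2-fold higher number from compound 1 to compound 2 (0.86 log units; beyond the scatter), where a whole naphthalen-1-yl replaced the 3-fluorophenyl. Among the compounds with values here, the swap of one halogen for another is a far smaller change, and no measured pair shows what it does here. The expected step in this assay is therefore a 1.2-fold lower number from compound 3 to compound 4 (0.07 log units; within the scatter), in no clear direction beyond the scatter. Compound 4 is estimated at 700 nM, within a range from 300 nM to 1700 nM.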

Compound 4, half-maximal inhibitory concentration: 197 nM
For compound 4 the middle estimate is 3.6-fold (0.55 log units) above the measured one; the measured number lies below the stated range.
By their numbers in this assay, from the lowest: compound 1; then compounds 4 and 2 (each within the scatter of the next); then compound 3.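

On the aromatic ring carried by the sulfonyl group, the identity of the halogen matters: in this assay, chloro in place of fluoro gives a 4.2-fold lower number from compound 3 to compound 4 (0.62 log units; beyond the scatter), a step beyond the scatter from exchanging one heavy atom for one other. Going by these compounds alone, the only earlier change at this group was the much larger replacement of 3-fluorophenyl by naphthalen-1-yl, which gave a 7.2-fold higher number from compound 1 to compound 2 (0.86 log units; beyond the scatter), so changes here are now seen to move the number in either direction, towards stronger inhibition in one pair and weaker in the other. Nothing measured here explains the difference between the two halogens.

From the compounds shown here alone, whether a bromo or a methyl at this same place would lower the number further remains open. Also open, going by these compounds, is whether the fluoro-to-chloro step would carry over to the core of compound 1, with its acetyl group and its dimethylamino side chain.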